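A few compounds are considered here, and "the series" means these few. Any claim that something is new, unique, unknown or untested is made for them only; others in the source may bear on it.

Compound 1 `COc1cc(C(=O)NS(=O)(=O)c2ccccc2C)ccc1Cc1c[nH]c2ccc(NC(=O)OC3CCCC3)cc12`: 1 nM
Compound 2 `COc1cc(C(=O)NS(=O)(=O)c2ccccc2C)ccc1Cc1cn(C(=O)N(C)C)c2ccc(NC(=O)OC3CCCC3)cc12`: 0.4 nM

Within the data shown here, in an assay on isolated protein for binding affinity to cysteinyl leukotriene receptor 1 (Cavia porcellus) (on this read-out lower numbers stand for stronger inhibition and higher numbers for weaker inhibition), compound 2 holds the lower of the two numbers; the gap to its only neighbour is a 2.5-fold lower number from compound 1 to compound 2 (0.40 log units; beyond the scatter). Compound 3 `COc1cc(C(=O)NS(=O)(=O)c2ccccc2C)ccc1Cc1cn(C(=O)NCCCc2ccccc2)c2ccc(NC(=O)OC3CCCC3)cc12` carries (3-phenylpropyl)amino in place of dimethylamino on a carbonyl carbon. Among the measured compounds shown here, the single measured step, a 2.5-fold lower number from compound 1 to compound 2 (0.40 log units; beyond the scatter), concerns a different place and says nothing about exchanging groups on that carbonyl carbon, so no step bears on this change. The expected step is therefore a 1.3-fold higher number from compound 2 to compound 3 (0.10 log units; within the scatter), nothing beyond the scatter in either direction. Compound 3 is estimated at 0.5 nM, within 0.15 nM to 2 nM.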

Compound 3, half-maximal inhibitory concentration: 0.5 nM
Estimate against measurement, compound 3: no gap at the digits printed; low and high end bracket the measured number.
By their numbers in this assay, from the lowest: compounds 2, 3 and 1 (each within the scatter of the next, the first and the last beyond it).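

On the carbonyl carbon, dimethylamino can give way to the far bigger (3-phenylpropyl)amino, with its six-membered aromatic ring and hydrogen-bond donor, without a change beyond the scatter in this assay (a 1.3-fold higher number from compound 2 to compound 3 (0.10 log units; within the scatter)). The (3-phenylpropyl)carbamoyl group in place of hydrogen on the aromatic nitrogen also stays within the scatter (a 2.0-fold lower number from compound 1 to compound 3 (0.30 log units; within the scatter)). Nothing available explains why such a large exchange leaves the number so little moved. Still open, going by these compounds, is how a longer chain, or a chain carrying a carboxylic acid or an amine, would behave on that carbonyl carbon.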